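Aryl swap on the fused ring of the aminomethyl series

A few compounds are considered here, and "the series" means these few. Any claim that something is new, unique, unknown or untested is made for them only; others in the source may bear on it.

Compound 1 `Cc1nc2cc(-c3ccco3)nn2c(-c2ccc(Cl)cc2Cl)c1CN` is tested in an assay on isolated protein for inhibition of Dipeptidyl peptidase 9 (Homo sapiens); on this read-out higher numbers stand for weaker inhibition and lower numbers for stronger inhibition. In this assay compound 1 gives only a limit, > 30000 nM, and no number. Compound 2 `Cc1nc2c(-c3ccccc3)cnn2c(-c2ccc(Cl)cc2Cl)c1CN` also returns a limit in this assay, > 30000 nM. What the series shows so far is the limit of > 30000 nM in this assay, at which 2 of the 2 values shown sit. Compound 3 `Cc1nc2cc(-c3ccccc3)nn2c(-c2ccc(Cl)cc2Cl)c1CN` differs from compound 1 by phenyl in place of furan-2-yl on an aromatic carbon. Within the data shown here, no measured step exists between these compounds, so no step beyond the scatter is expected in this assay. Compound 3 is expected to sit at about 40000 nM, within 15000 nM to 150000 nM, most likely again as a limit. That estimate means a step that the limit leaves unreadable from compound 1 to compound 3.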

Compound 3, inhibition constant: > 20000 nM
Compound 3 was reported as a limit; the forecaster's own chance of this, stated with the estimate: 85%; the middle value lies beyond the limit too.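

In this assay, compound 1 and compound 3 both return limits, so no step can be read between them. The compounds shown leave open whether furan-2-yl and phenyl differ at all in this inhibition.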